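Replacing the isopropyl amide group in a cytotoxicity series

The source may report more compounds than this note shows. Statements on the series, on what has been measured and on what is new or still open speak of the compounds shown alone.

Compound 1 `CCN(CC)c1ccc2cc(C(=O)NC(C)C)c(=O)oc2c1` stands at the limit of a functional assay on HCT-116 cells (Homo sapiens) for cytotoxicity, read by MTT assay, with a stated time of 72 h; on this read-out lower numbers stand for stronger inhibition and higher numbers for weaker inhibition; in this assay compound 1 gives > 100000 nM, which is a limit rather than a number. Compound 2 `CCOc1ccc2cc(C(=O)NN)c(=O)oc2c1` likewise gives > 100000 nM in this assay, again a limit. Among the compounds with values here, both measured values thus sit at the limit of > 100000 nM in this assay, at which 2 of the 2 values shown sit, so no step between measured compounds can be judged. Compound 3 `CCN(CC)c1ccc2cc(C(=O)N/N=C(/C)c3cccnc3)c(=O)oc2c1` differs from compound 1 by a group of 9 heavy atoms (7 carbon, 2 nitrogen; one six-membered aromatic ring with 1 hetero atom) in place of a group of 3 heavy atoms (3 carbon; no ring), on an amide-type nitrogen. Within the data shown here, with no measured step to lean on, the expected step of an at least 3.3-fold lower number from compound 1 to compound 3 (0.52 log units; beyond the scatter) in this assay is uncertain in size and direction, and a limit is again possible. Compound 3 is estimated at 30000 nM in this assay, within 5000 nM to 200000 nM.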

Compound 3, half-maximal inhibitory concentration: > 100000 nM
Compound 3 was reported as a limit; the forecaster's own chance of this, stated with the estimate: 45%; at least 3.3-fold (0.52 log units) between middle value and limit.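

No step from compound 1 to compound 3 can be read, since both stand at a limit: the limit of > 100000 nM in this assay, at which 3 of the 3 values shown sit.

The compounds shown leave open whether any group on the amide-type nitrogen gives a measurable value in this assay.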